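Chloro replaces dimethyl on the pendant phenyl ring

The source may report more compounds than this note shows. Statements on the series, on what has been measured and on what is new or still open speak of the compounds shown alone.

Three compounds share a core that carries a pendant aryl ring, and differ only in that ring. Compound 1 `COc1cc(-n2cnc3ccc(-c4cccc(N)c4)cc32)cc(OC)c1OC` bears a 3-aminophenyl group and in a functional assay on MCF7 cells (Homo sapiens) for antiproliferative activity, read by MTT assay, with a stated time of 72 h (on this read-out lower numbers stand for stronger inhibition and higher numbers for weaker inhibition), compound 1 gives 180 nM. Compound 2 `COc1cc(-n2cnc3ccc(-c4cccc(C)c4C)cc32)cc(OC)c1OC` bears a 2,3-dimethylphenyl group, and in this assay compound 2 gives 2150 nM. Compound 3 `COc1cc(-n2cnc3ccc(-c4ccccc4)cc32)cc(OC)c1OC` bears a plain phenyl group, and in this assay compound 3 gives 2290 nM. Among these three numbers, compound 2 stands second highest: its number and that of compound 3 lie within the scatter of each other (a 1.1-fold higher number from compound 2 to compound 3 (0.03 log units; within the scatter)), while compound 1 is far away (a 12-fold higher number from compound 1 to compound 2 (1.08 log units; beyond the scatter)).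

Compound 4 `COc1cc(-n2cnc3ccc(-c4cccc(Cl)c4)cc32)cc(OC)c1OC` is not yet measured. The change from compound 2 is 3-chlorophenyl in place of 2,3-dimethylphenyl on an aromatic carbon. For the measured compounds named here, two measured steps bear on it. The step of a 1.1-fold higher number from compound 2 to compound 3 (0.03 log units; within the scatter) shows that losing the two methyl groups changes little. Going by the values given here, the step of a 13-fold higher number from compound 1 to compound 3 (1.10 log units; beyond the scatter) shows that a substituent at the same position of the phenyl ring can matter greatly, but the only substituent measured there is amino, and no step tells what chlorine does. Compound 4 is therefore expected to move modestly, a 1.7-fold lower number from compound 2 to compound 4 (0.22 log units; within the scatter), with wide uncertainty. The estimate for compound 4 is 1300 nM, within a range from 400 nM to 4000 nM.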

Compound 4, half-maximal inhibitory concentration: 3120 nM
Beside the measured number, compound 4's estimate is 2.4-fold (0.38 log units) below it; the range from low to high includes it.
By their numbers in this assay, from the lowest: compound 1; then compounds 2, 3 and 4 (each within the scatter of the next).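

In this assay, for the compounds shown here, chloro in place of hydrogen on the pendant ring gives a 1.4-fold higher number from compound 3 to compound 4 (0.13 log units; within the scatter) and so stays within the scatter, which shows that a substituent at this position does not by itself bring the strong inhibition seen with amino, the only substituent the earlier compounds had tested there. Chloro in place of amino gives a 17-fold higher number from compound 1 to compound 4 (1.24 log units; beyond the scatter) and lies clearly beyond the scatter, while 3-chlorophenyl in place of 2,3-dimethylphenyl gives a 1.5-fold higher number from compound 2 to compound 4 (0.16 log units; within the scatter) and stays within it, so compounds 2, 3 and 4 sit together and, among these four pendant rings, only the 3-aminophenyl group of compound 1 stands apart. No measurement offered here accounts for the gap between amino and chloro at this position.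

On these data alone, it remains open whether the number of compound 1 belongs to the amino group alone or would also be reached with a hydroxyl, a methylamino, a dimethylamino or an acetamide group on the same carbon. A carboxylic acid or an aminomethyl chain there is equally untold, as is what amino would do on a different carbon of the pendant ring.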